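The source may report more compounds than this note shows. Statements on the series, on what has been measured and on what is new or still open speak of the compounds shown alone.

Going by the values given here, compound 1, with the structure `CSc1ncc(-c2ccc(S(C)(=O)=O)cc2)n1-c1ccc(F)cc1`, is the lower of the two compounds measured so far in a functional assay on the whole organism (strain Sprague-Dawley) with Rattus norvegicus as the target, read by paw edema, with a stated time of 5 h, at a dose of 50 mg/kg by the oral route; on this read-out higher numbers stand for more inhibition at the one dose given (going by the name of the read-out) and lower numbers for less inhibition. In this assay compound 1 gives 18.7%, while compound 2, with the structure `CCSc1ncc(-c2ccc(S(C)(=O)=O)cc2)n1-c1ccc(F)cc1`, gives 43%; the step of a number 24.3 percentage points higher from compound 1 to compound 2 (beyond the scatter) arises from a methyl in place of hydrogen on a saturated chain carbon bound to a sulfur.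

Compound 3, with the structure `CSc1ncc(-c2ccc(S(C)(=O)=O)cc2)n1-c1ccc(Cl)cc1`, has not yet been measured. It differs from compound 1 by chloro in place of fluoro on an aromatic carbon, that is, on an aromatic carbon of a six-membered aromatic ring of carbon only, para to a large group. Among the compounds with values here, no measured step touches this part of the shared core; the only step known concerns the chain on the sulfur, so nothing in the data speaks directly to a swap of halogen on the ring. The author therefore expects a step of a number 5.3 percentage points higher from compound 1 to compound 3 (within the scatter) that stays within the usual scatter of this assay, in either direction. The estimate for compound 3 in this assay is 24%, with a range from 5% to 48%.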

Compound 3, a percentage reported as inhibition, in the whole organism at one dose (the size of the read-out at that dose, not a potency): 42.7%
Compound 3: the middle estimate sits 18.7 percentage points below what was measured; low and high end bracket the measured number.
By their numbers in this assay, from the lowest: compound 1; then compounds 3 and 2 (each within the scatter of the next).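

In this assay, going by these compounds alone, the swap of halogen gives a number 24 percentage points higher from compound 1 to compound 3 (beyond the scatter) and so shows that this place on an aromatic carbon, para to a large group, responds to a single-atom change, something the earlier compounds could not show, as they differ only in the chain on the sulfur. Together with a number 24.3 percentage points higher from compound 1 to compound 2 (beyond the scatter) on that chain, this gives two separate places on the shared core of compound 1 where one change moves the inhibition beyond the scatter at the one dose given. Nothing available bears on what lies behind the step from fluoro to chloro.

The compounds shown leave open whether the two changes would add up, as none of them carries the 4-chlorophenyl group together with the longer chain of compound 2. They also leave open how a bromo or methoxy group, or plain hydrogen, would read at this place on the ring, and how a propyl chain would read on the sulfur.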